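This account rests on a few compounds, and the source may have more. Where it says the series, first, only, none or still open, it means among the compounds named here.

Compound 1 `O=Cc1ccc(-c2cn3ccnc3c(-c3ccc4ncn(C5CCCCC5)c4c3)n2)cc1` gives 20.9% in a functional assay on EKVX cells (Homo sapiens) for inhibition, read by sulforhodamine B assay, with a stated time of 48 h, tested at 10 uM; on this read-out lower numbers stand for less inhibition and higher numbers for more inhibition at the one concentration tested (going by the name of the read-out).
Compound 2 `Clc1ccc(-c2cn3ccnc3c(-c3ccc4ncn(C5CCCCC5)c4c3)n2)cc1` gives 13.1% in this assay.

Compound 2 stands lowest of the two numbers, though the step of a number 7.8 percentage points lower from compound 1 to compound 2 (within the scatter) lies within the scatter. Compound 3 `COc1ccccc1-c1cn2ccnc2c(-c2ccc3ncn(C4CCCCC4)c3c2)n1` carries the change (2-methoxyphenyl in place of 4-chlorophenyl on an aromatic carbon). Within the data shown here, the only measured step, a number 7.8 percentage points lower from compound 1 to compound 2 (within the scatter), also swapped the group on that aromatic carbon and stayed within the scatter, so no step beyond the scatter is expected here either. Compound 3 is estimated at 17%, between 5% and 30%. This expectation means a step of a number 3.9 percentage points higher from compound 2 to compound 3 (within the scatter).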

Compound 3, a percentage reported as inhibition, at one concentration (the size of the read-out at that concentration, not a potency): 13.4%
Compound 3: middle estimate off by 3.6 percentage points, on the high side; low and high end bracket the measured number.
By their numbers in this assay, from the lowest: compounds 2, 3 and 1 (each within the scatter of the next).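

In this assay the swap to 2-methoxyphenyl shows a number 0.3 percentage points higher from compound 2 to compound 3 (within the scatter) against 4-chlorophenyl, and a number 7.5 percentage points lower from compound 1 to compound 3 (within the scatter) against 4-formylphenyl. A third aryl group on this aromatic carbon, with a different substituent in a different ring position, therefore still gives no step beyond the scatter, so these three groups cannot be told apart here. Nothing measured here offers a reason for this.

Still open, on these data alone, is whether a group of another kind on this phenyl ring, such as an amine or a carboxylic acid, would produce a step beyond the scatter.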